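Pyridinyl for pyrazolyl: lipophilicity outlook for compound 4

The compounds below may be only part of what the source reports. "The series", "measured", "known", "first", "only" and "open" are said of these compounds alone.

Compound 1, `Cc1noc(C)c1-c1ccc(-c2nnc(N(C)Cc3ccc4nccn4c3)o2)cc1`: 3.1
Compound 2, `Cc1nc(-c2c(C)nn(C)c2C)ccc1-c1nnc(N(C)Cc2ccc3nccn3c2)o1`: 2.5
Compound 3, `Cc1cc(-c2c(C)nn(C)c2C)cnc1-c1nnc(N(C)Cc2ccc3ncc(-c4cnn(CCN(C)C)c4)n3c2)o1`: 2.7

In a physicochemical assay for lipophilicity, at pH 7.4 (a lower number here means a more polar compound, a higher number a more lipophilic compound), compound 3 stands second highest of the three values. Its nearest neighbour is compound 2, whose value lies within the scatter of that of compound 3, so the two are not distinguished; compound 1 lies furthest away, beyond the scatter. Compound 4, `Cc1cc(-c2c(C)nn(C)c2C)cnc1-c1nnc(N(C)Cc2ccc3ncc(-c4ccc(CN(C)C)nc4)n3c2)o1`, has not yet been measured. It differs from compound 3 by 6-((dimethylamino)methyl)pyridin-3-yl in place of 1-(2-(dimethylamino)ethyl)-1H-pyrazol-4-yl on an aromatic carbon. Within the data shown here, no measured pair shows this exchange, so only an expectation is possible. A small rise in this assay is expected, of the size a number 0.20 log units higher from compound 3 to compound 4 (within the scatter), at the edge of the scatter. Compound 4 is therefore estimated at 2.9, in the range 2.4 to 3.4.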

Compound 4, distribution coefficient: 2.5
Compound 4: middle estimate off by 0.40 log units, on the high side, and the stated range covers the measured number.
By their numbers in this assay, from the lowest: compounds 2, 4 and 3 (each within the scatter of the next); then compound 1.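

On an aromatic carbon of the five-membered ring, 6-((dimethylamino)methyl)pyridin-3-yl in place of 1-(2-(dimethylamino)ethyl)-1H-pyrazol-4-yl gives a number 0.20 log units lower from compound 3 to compound 4 (within the scatter) in this assay, so compound 3 and compound 4 are not distinguished. This is the only exchange at this position among the compounds shown, and it swaps a five-membered aromatic ring with 2 hetero atoms for a six-membered aromatic ring with 1 hetero atom. Nothing available explains this result.

The compounds shown leave open how this assay responds at this position to a group with no dimethylamino end, such as a carboxylic acid or a morpholine. They also leave open whether a longer chain ending in the dimethylamino group would stand apart from compound 3.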